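Cytotoxicity notes on a boron-containing series

This account rests on a few compounds, and the source may have more. Where it says the series, first, only, none or still open, it means among the compounds named here.

Compound 1 `OB1OCc2ccc(-n3cc(Sc4cccc(Cl)c4)c4ccccc43)cc21` and compound 2 `Cc1cccc(C(=O)c2ccn(-c3ccc4c(c3)B(O)OC4)c2)c1` were both run in an ADME assay on L929 cells (Mus musculus) for cytotoxicity, read by resazurin assay, with a stated time of 72 h; on this read-out higher numbers stand for weaker inhibition and lower numbers for stronger inhibition. Compound 1 reaches only the limit, > 10 ug/mL. Compound 2 likewise sits at the limit, > 10 ug/mL, so no number places it within the series. Both results rest at the limit of > 10 ug/mL in this assay, at which 2 of the 2 values shown sit. Compound 3 `Cc1ccc(C(=O)c2ccn(-c3ccc4c(c3)B(O)OC4)c2)s1` has not been tested; it differs from compound 2 by 5-methylthiophen-2-yl in place of 3-methylphenyl on a carbonyl carbon. Among the compounds with values here, no measured step between two compounds exists here, so the step that the limit leaves unreadable from compound 2 to compound 3 is expected to stay within the scatter, with no direction. Compound 3 is therefore estimated at 15 ug/mL, within 7 ug/mL to 40 ug/mL, most likely again reported only as a limit.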

Compound 3, half-maximal inhibitory concentration: > 10 ug/mL
Compound 3: only a limit was reported (the forecaster's own chance of this, stated with the estimate: 85%); the middle value does not contradict the limit.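

No step can be read between compound 2 and compound 3 in this assay, as both are reported only as limits: the limit of > 10 ug/mL in this assay, at which 3 of the 3 values shown sit.

The compounds shown leave open whether 5-methylthiophen-2-yl and 3-methylphenyl on a carbonyl carbon differ at all in this read-out.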